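Benzylamide Series: Side-Chain Oxygen Versus Alkyl

A few compounds are considered here, and "the series" means these few. Any claim that something is new, unique, unknown or untested is made for them only; others in the source may bear on it.

Measured compounds:
compound 1 `C=CCOCC(N)C(=O)NCc1ccccc1` 45 mg/kg
compound 2 `CCCC[C@@H](N)C(=O)NCc1ccccc1` 23 mg/kg

Both compounds share the benzylamide core and differ only in the side chain. In a functional assay on the whole organism (strain NMRI) with Mus musculus as the target, in the maximal electroshock model, with a stated time of 30 min (a higher number here means that more compound is needed for the effect, a lower number that less compound is needed), compound 2 gives 23 mg/kg and compound 1 gives 45 mg/kg; the two numbers lie within the scatter of each other, so no order between them can be read.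

Compound 3 `N[C@H](CCO)C(=O)NCc1ccccc1` is not yet measured in this assay. Against compound 2 its change is hydroxy in place of ethyl on a saturated chain carbon, three bonds along the chain from an amine nitrogen and a carbonyl carbon, the hydroxyethyl chain of compound 3 thus standing where the butyl chain of compound 2 stood.

Neither measured pair provides a step to lean on, so the expectation rests on the change alone. Compound 3 is expected to need a larger dose than compound 2, and the expected step from compound 2 to compound 3 is a 2.6-fold higher number from compound 2 to compound 3 (0.42 log units; beyond the scatter). For compound 3 the estimate is 60 mg/kg, within a range of 25 mg/kg to 150 mg/kg.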

Compound 3, dose for half-maximal effect: > 160 mg/kg
Compound 3: no number, only a limit; the forecaster's own chance of this, stated with the estimate: 15%; at least 2.6-fold (0.42 log units) between middle value and limit.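

Hydroxy in place of ethyl on a saturated chain carbon, three bonds along the chain from an amine nitrogen and a carbonyl carbon, gives the first readable step in the series in this assay: an at least 6.9-fold higher number from compound 2 to compound 3 (0.84 log units; beyond the scatter). The butyl chain of compound 2 therefore cannot be exchanged for a 2-hydroxyethyl chain at this position without a clear rise in the dose needed. From the compounds shown here alone, compound 3 carries only a limit in this assay, not a number, so the full size of the step stays unknown: the limit of > 160 mg/kg in this assay, at which 1 of the 3 values shown sits.

The exchange both shortens the chain and adds the hydroxy, and the compounds shown do not separate these two parts. A plain propyl chain, or a longer chain ending in hydroxy, methoxy or an amine, would bear on this question.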